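Two weak inhibitors and a hydrazone variant awaiting measurement

A few compounds are considered here, and "the series" means these few. Any claim that something is new, unique, unknown or untested is made for them only; others in the source may bear on it.

Measured so far:
compound 1, `O=C(NNc1nc2ccccc2nc1Cc1ccccc1)c1ccc(Br)cc1`, 980000 nM
compound 2, `O=C(Cn1c(=O)c(Cc2ccccc2)nc2ccccc21)NNC(=O)c1ccc(Cl)cc1`, 880000 nM

In an assay for inhibition of Amine oxidase [flavin-containing] B (Bos taurus), read by fluorescence, with a stated time of 60 min (on this read-out lower numbers stand for stronger inhibition and higher numbers for weaker inhibition), compound 1 gives 980000 nM. In this assay compound 2 gives 880000 nM. The two numbers lie within the scatter of each other, so neither compound can be called the stronger; both are very weak on this read-out.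

Compound 3, `O=C(Cn1c(=O)c(Cc2ccccc2)nc2ccccc21)N/N=C/c1ccc(Br)cc1`, is not yet measured. It differs from compound 2 in one place: a group of 9 heavy atoms (7 carbon, 1 nitrogen, 1 bromine; one six-membered aromatic ring of carbon only) in place of a group of 10 heavy atoms (7 carbon, 1 nitrogen, 1 oxygen, 1 chlorine; one six-membered aromatic ring of carbon only), on an amide-type nitrogen. The acyl hydrazide end of compound 2 thus becomes a hydrazone carrying a brominated ring. Among the measured compounds shown here, no pair of measured compounds shows the effect of such a change, so there is nothing to lean on here. Compound 3 is expected to stay close to compound 2, with a step from a 1.3-fold lower number from compound 2 to compound 3 (0.10 log units; within the scatter) that is likely no larger than the scatter. The estimate for compound 3 is 700000 nM, with a range from 200000 nM to 2500000 nM.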

Compound 3, half-maximal inhibitory concentration: 26000 nM
Beside the measured number, compound 3's estimate is 27-fold (1.43 log units) above it; measured number outside the range, below it.
By their numbers in this assay, from the lowest: compound 3; then compounds 2 and 1 (each within the scatter of the next).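

In this assay, among the compounds shown here, exchanging the ((4-chlorophenyl)carbonyl)amino group on the amide-type nitrogen for the brominated hydrazone group gives a 34-fold lower number from compound 2 to compound 3 (1.53 log units; beyond the scatter), the first step that can be read, and it shows that a change at this place can move the number far beyond the scatter. The change is not a single one: chlorine gives way to bromine, the carbonyl of the leaving group is gone, and the entering group has 0 hydrogen-bond donors where the leaving group has 1. No measurement shown here bears on why the number falls so far.

These changes arrive together, so the compounds shown cannot tell how much each one contributes. From the compounds shown here alone, it also remains open how the hydrazone would fare with chlorine, a methoxy group or an amine on its ring in place of bromine.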